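The source may hold more compounds than are shown below. What is called first, only, known or untested is meant among the compounds shown, and "the series" means these compounds.

Measured in an assay on isolated protein (Cavia porcellus) with Sigma non-opioid intracellular receptor 1 (Homo sapiens) as the target, read by radioligand binding; a lower number here means a stronger inhibitor, a higher number a weaker inhibitor:
compound 1, `O=c1cc(-c2ccccc2)oc2cccc(OCCCN3CCC(O)CC3)c12`: 91 nM
compound 2, `O=c1cc(-c2ccccc2)oc2cccc(OCCCCN3CCC(O)CC3)c12`: 177 nM
compound 3, `CN(C)CCCCCCCCCCOc1ccc2oc(-c3ccccc3)cc(=O)c2c1`: 341 nM

Compound 3 gives the highest of the three numbers; against compound 2 the gap lies within the scatter, against compound 1 it lies beyond it. Compound 4, `CCN(CC)CCCCCCOc1ccc2oc(-c3ccccc3)cc(=O)c2c1`, has not yet been measured. It differs from compound 3 by diethylamino in place of 4-(dimethylamino)butyl on a saturated chain carbon, six bonds along the chain from an oxygen on an aromatic ring, so the chain is shorter and the amine carries larger groups. Only one measured step is shown, a 1.9-fold higher number from compound 1 to compound 2 (0.29 log units; within the scatter), a chain lengthening that changed nothing beyond the scatter. No shown step moves a chain this far or swaps the amine substituents, so the expected change is small: compound 4 is estimated at 250 nM (range 90 nM to 700 nM), a step of a 1.4-fold lower number from compound 3 to compound 4 (0.13 log units; within the scatter).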

Compound 4, half-maximal inhibitory concentration: 100 nM
Beside the measured number, compound 4's estimate is 2.5-fold (0.40 log units) above it; the measured number falls inside the stated range.
By their numbers in this assay, from the lowest: compounds 1, 4, 2 and 3 (each within the scatter of the next, the first and the last beyond it).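

In this assay, going by these compounds alone, diethylamino in place of 4-(dimethylamino)butyl gives a 3.4-fold lower number from compound 3 to compound 4 (0.53 log units; beyond the scatter), so a change at this place on the chain can move the number beyond the scatter, which the one earlier step did not do. Chain length and the groups on the amine change together here, so the step cannot be divided between them. Nothing available explains the shift. Still open, from the compounds shown here alone, is how dimethylamino would read on the shorter chain of compound 4, or diethylamino on the longer chain of compound 3. Going by these compounds, a morpholine at the chain end is also open.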